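A few compounds are considered here, and "the series" means these few. Any claim that something is new, unique, unknown or untested is made for them only; others in the source may bear on it.

Measured compounds:
Compound 1, `CC1=CC[C@H](C(C)(C)NC(=S)NN)CC1`. In an ADME assay on Vero cells (Chlorocebus sabaeus) for inhibition, read by sulforhodamine B assay, with a stated time of 48 h (on this read-out higher numbers stand for weaker inhibition of growth and lower numbers for stronger inhibition of growth), compound 1 gives > 100000 nM, a limit of the assay.
Compound 2, `CC1=CC[C@H](C(C)(C)NC(=S)N/N=C/c2ccccc2)CC1`. In this assay compound 2 gives > 100000 nM, again only a limit.
Compound 3, `CC1=CC[C@H](C(C)(C)NC(=S)N/N=C/c2ccccc2Cl)CC1`. In this assay compound 3 gives > 100000 nM, also a limit.

Compound 2 therefore stands at the assay limit, as do the two other values, (the limit of > 100000 nM in this assay, at which 3 of the 3 values shown sit). Among the compounds with values here, the only single-point step among them, a step that the two limits leave unreadable from compound 2 to compound 3, cannot be sized. Compound 4, `CC1=CC[C@H](C(C)(C)NC(=S)N/N=C/c2cccs2)CC1`, differs from compound 2 by thiophen-2-yl in place of phenyl on a carbon with a double bond to nitrogen. Within the data shown here, no measured step bears readably on this change, so the account expects no step beyond the scatter; compound 4 is expected to sit at the limit as well, estimated at 100000 nM with a range of 30000 nM to 300000 nM, a step of a number no higher from compound 2 to compound 4 (the limit leaves the size open).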

Compound 4, concentration for total growth inhibition: 13400 nM
Compound 4: the middle estimate sits 7.5-fold (0.87 log units) above what was measured, outside the stated range (below it).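

In this assay thiophen-2-yl, on a carbon with a double bond to nitrogen, gives the first readable value, so the group at this place can change growth inhibition: there is an at least 7.4-fold lower number from compound 2 to compound 4 (0.87 log units; beyond the scatter) and, against 2-chlorophenyl, an at least 7.4-fold lower number from compound 3 to compound 4 (0.87 log units; beyond the scatter). The hydrazine end without any such group shows the same direction, with an at least 7.4-fold lower number from compound 1 to compound 4 (0.87 log units; beyond the scatter). All three sizes are only lower bounds, set by one shared limit: (the limit of > 100000 nM in this assay, at which 3 of the 4 values shown sit).

As far as these compounds go, whether the sulfur atom matters remains open, since furan-2-yl would test that. Whether a pyridin-2-yl ring would also lower the number is equally unsettled.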